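A 4-Chlorophenyl Swap on the Sulfonyl Sulfur

This account rests on a few compounds, and the source may have more. Where it says the series, first, only, none or still open, it means among the compounds named here.

Compound 3 (`Cc1ccccc1S(=O)(=O)Nc1ccc(-c2nc3ccccc3o2)cc1`) stands at > 100000 nM in an ADME assay on HEK293 cells (Homo sapiens) for cytotoxicity, read by resazurin assay, with a stated time of 48 h (a higher number here means that more compound is tolerated, a lower number that less compound is tolerated), and that is a limit of the assay, not a number. Compound 1 (`O=S(=O)(Nc1ccc(-c2nc3ccccc3o2)cc1)c1ccc(Cl)s1`) gives > 100000 nM in this assay and that too is a limit. Compound 2 (`COc1cccc(S(=O)(=O)Nc2ccc(-c3nc4ccccc4o3)cc2)c1`) gives > 100000 nM in this assay and that is a limit as well. The three share the limit of > 100000 nM in this assay, at which 3 of the 3 values shown sit, and cannot be ranked against one another.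

The change to compound 4 (`O=S(=O)(Nc1ccc(-c2nc3ccccc3o2)cc1)c1ccc(Cl)cc1`) is 4-chlorophenyl in place of 2-methylphenyl on a sulfonyl sulfur on a sulfonyl sulfur, with 4-chlorophenyl in place of 2-methylphenyl. For the measured compounds named here, three measured steps bear on it, all swaps on that same sulfur, namely a step that the two limits leave unreadable from compound 1 to compound 2 and a step that the two limits leave unreadable from compound 1 to compound 3 and a step that the two limits leave unreadable from compound 2 to compound 3 and none of them has a readable size. Going by the values given here, the nearest precedent is compound 1, whose 5-chlorothiophen-2-yl also carries chlorine and whose > 100000 nM is again a limit. No step beyond the scatter is therefore expected in this assay and no direction can be named. The expected move is a number no higher from compound 3 to compound 4 (the limit leaves the size open) and the reading will most likely be a limit again. Compound 4 is estimated at 100000 nM with a range from 50000 nM to 200000 nM in this assay.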

Compound 4, half-maximal cytotoxic concentration: > 100000 nM
Compound 4: only a limit was reported; the forecaster's own chance of this, stated with the estimate: 85%; the middle value lies on the limit itself.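

In this assay compound 4 gives > 100000 nM, and that is a limit of the assay. For the compounds shown here, no step from compound 1, compound 2 or compound 3 to compound 4 can be read: the limit of > 100000 nM in this assay, at which 4 of the 4 values shown sit. The compounds shown leave open whether any group on the sulfonyl sulfur would give a value readable as a number in this assay.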